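This account rests on a few compounds, and the source may have more. Where it says the series, first, only, none or still open, it means among the compounds named here.

In a functional assay on RAW264.7 cells (Mus musculus) for inhibition, read by ELISA, with a stated time of 24 h (on this read-out higher numbers stand for an effect only at larger amounts of compound and lower numbers for an effect already at smaller amounts), compound 1 (`CC/C=C\C[C@H]1C(=O)C=C[C@H]1CC(=O)OCCC`) gives 23000 nM and compound 2 (`CC/C=C\C[C@H]1C(=O)C=C[C@H]1CC(=O)Oc1ccccc1`) gives 33000 nM on the same core. Among the measured compounds shown here, these are the only two numbers available, and they cannot be told apart, so compound 2 stands level with compound 1 rather than apart from it. The next compound to be tested is compound 3 (`CC/C=C\C[C@H]1C(=O)C=C[C@H]1CC(=O)OCc1ccccc1`), which carries benzyl in place of phenyl on an oxygen next to a carbonyl group. For the measured compounds named here, one measured step bears on this change, and it concerns the same place on the molecule: a 1.4-fold higher number from compound 1 to compound 2 (0.16 log units; within the scatter) with phenyl in place of propyl. That step stayed within the normal spread of repeat measurements, so swapping one group for another here has not yet moved the number. Neither measured compound carries benzyl, which leaves this a thin basis, and no step beyond the scatter is expected in either direction. For compound 3 the estimated step is a 1.3-fold lower number from compound 2 to compound 3 (0.10 log units; within the scatter) and no real change is expected. Compound 3 is expected at 26000 nM with an estimated range from 11000 nM to 60000 nM for this measurement.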

Compound 3, half-maximal effective concentration: 20000 nM
For compound 3 the middle estimate is 1.3-fold (0.11 log units) above the measured one; the range from low to high includes it.
By their numbers in this assay, from the lowest: compounds 3, 1 and 2 (each within the scatter of the next).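

Benzyl in place of phenyl on an oxygen next to a carbonyl group gives a 1.7-fold lower number from compound 2 to compound 3 (0.22 log units; within the scatter), and the comparison with the propyl compound gives a 1.2-fold lower number from compound 1 to compound 3 (0.06 log units; within the scatter), with phenyl in place of ethyl on a saturated chain carbon bound to an oxygen next to a carbonyl group. In this assay, among the compounds shown here, this position has now carried three different groups, a propyl chain, a phenyl ring and a benzyl group, and no step among them lies beyond the usual scatter, so the earlier lack of change was not particular to one swap. Nothing measured here offers an explanation for this flat picture.

As far as these compounds go, all three groups are built from carbon and hydrogen alone, so it remains open whether an amine, a carboxylic acid or a much longer chain at this place would move the number beyond the scatter. From the compounds shown here alone, it is also open whether an amide in place of this link, or changes elsewhere on the shared core, would matter more than the group swaps seen so far.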